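The source may report more compounds than this note shows. Statements on the series, on what has been measured and on what is new or still open speak of the compounds shown alone.

Measured compounds in a functional assay on MCF7 cells (Homo sapiens) for cytotoxicity, read by MTT assay, with a stated time of 72 h; a lower number here means a stronger inhibitor, a higher number a weaker inhibitor:
Compound 1 `COc1ccc(/C(=C(/CCCl)c2ccccc2)c2ccccc2)cc1`: > 50000 nM, a limit of the assay.
Compound 2 `COc1ccc(/C(=C(/CCNC(=O)N2CCCCC2)c2ccccc2)c2ccccc2)cc1`: > 50000 nM, a limit of the assay.
Compound 3 `COc1ccc(/C(=C(/CCNC(=O)C(=O)N2CCCC2)c2ccccc2)c2ccccc2)cc1`: > 50000 nM, a limit of the assay.

Compound 3 stands only at a limit in this assay, as do the other two values: the limit of > 50000 nM in this assay, at which 3 of the 3 values shown sit. Compound 4 `COc1ccc(/C(=C(/CCNC(=O)C(=O)N2CCCCC2)c2ccccc2)c2ccccc2)cc1` differs from compound 3 by piperidin-1-yl in place of pyrrolidin-1-yl on a carbonyl carbon. Among the compounds with values here, the steps that bear on this are a step that the two limits leave unreadable from compound 1 to compound 2, a step that the two limits leave unreadable from compound 1 to compound 3 and a step that the two limits leave unreadable from compound 2 to compound 3; the last of these is the nearest comparison, a change of ring on a carbonyl carbon, and none of the three is readable in size. No direction can be read from the measured steps. The expectation is that compound 4 again sits at the limit, so the step that the limit leaves unreadable from compound 3 to compound 4 is expected to be unreadable too. Compound 4 is estimated at 100000 nM, within a range from 50000 nM to 300000 nM, most likely reported only as a limit.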

Compound 4, half-maximal inhibitory concentration: > 50000 nM
Compound 4 ended at the assay's limit (the forecaster's own chance of this, stated with the estimate: 90%); the middle value lies beyond the limit too.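

The steps from compound 1, compound 2 and compound 3 to compound 4 cannot be read, since all four compounds stand only at a limit: the limit of > 50000 nM in this assay, at which 4 of the 4 values shown sit.

The compounds shown leave open which change to the shared core, if any, would give a value that is a number and not a limit.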